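Removing One Methoxy Group from Compound 1

The source may hold more compounds than are shown below. What is called first, only, known or untested is meant among the compounds shown, and "the series" means these compounds.

Compound 1 `COc1cccc(/C=C2\CCCc3ccccc3C2=O)c1OC`: 8580 nM
Compound 2 `COc1ccc(/C=C2\CCCc3ccccc3C2=O)cc1OC`: 8190 nM

Both compounds were tested in a functional assay on P388 cells (Mus musculus) for inhibition; a lower number here means a stronger inhibitor, a higher number a weaker inhibitor. Compound 1 stands level with compound 2, since their two values lie within the usual scatter of repeated measurements and cannot be ranked.

The next compound to be measured is compound 3 `COc1ccccc1/C=C1\CCCc2ccccc2C1=O`. It has hydrogen in place of methoxy on an aromatic carbon, ortho to a methoxy group and meta to a large group (hydrogen in place of methoxy on an aromatic carbon).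

Among the compounds with values here, no measured pair shows what removing a methoxy group does, so this expectation is tentative. Compound 1 at 8580 nM and compound 2 at 8190 nM place their methoxy groups differently, yet their values are close, so no change beyond the scatter is expected. The estimated change is a 1.1-fold lower number from compound 1 to compound 3 (0.03 log units; within the scatter). For compound 3 the expected value is 8000 nM, within an estimated range of 3000 nM to 20000 nM.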

Compound 3, half-maximal inhibitory concentration: 18000 nM
Compound 3: middle estimate off by 2.3-fold (0.35 log units), on the low side, and the stated range covers the measured number.
By their numbers in this assay, from the lowest: compounds 2 and 1 (each within the scatter of the next); then compound 3.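

In this assay, putting hydrogen in place of this methoxy group gives a 2.1-fold higher number from compound 1 to compound 3 (0.32 log units; beyond the scatter) and so weakens inhibition modestly, though beyond the scatter. Within the data shown here, this is the first sign that a methoxy group at this place, ortho to a methoxy group and meta to a large group, matters at all: compound 1, which keeps it, is the stronger inhibitor of the pair. No available measurement explains why the number rises.

The compounds shown do not reveal whether another group at this place, such as a hydroxyl, a fluorine or an ethoxy group, would match methoxy or do better. They also leave open whether taking away the other methoxy group of compound 1 would have a similar effect.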